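This account rests on a few compounds, and the source may have more. Where it says the series, first, only, none or still open, it means among the compounds named here.

Compound 1, `CC1(C)CC(N)=Nc2ccc(Cl)cc21`, gives 81% in a functional assay on MDA-MB-231 cells (Homo sapiens) for cytotoxicity, read by MTT assay, with a stated time of 72 h, tested at 5 uM, in the absence of a further agent; a lower number here means a stronger effect, a higher number a weaker effect of the compound at the concentration tested.
Compound 2, `CCNC1=Nc2ccc(Cl)cc2C(C)(C)C1`, gives 85.1%.
Compound 3, `CN(C)CCCNC1=Nc2ccc(Cl)cc2C(C)(C)C1`, gives 38%.

Among these three, compound 3 stands lowest: the step of a number 43 percentage points lower from compound 1 to compound 3 (beyond the scatter) and the step of a number 47.1 percentage points lower from compound 2 to compound 3 (beyond the scatter) both lie beyond the scatter, whereas the step of a number 4.1 percentage points higher from compound 1 to compound 2 (within the scatter) does not. The two amines without a dimethylamino-bearing chain therefore sit close to each other, and only compound 3 stands apart.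

Compound 4, `CN(C)CCNC1=Nc2ccc(Cl)cc2C(C)(C)C1`, has not yet been measured in this assay. It differs from compound 3 as follows: dimethylamino in place of (dimethylamino)methyl on a saturated chain carbon, two bonds along the chain from an amine nitrogen. The chain carrying the dimethylamino group is kept but shortened.

The step that bears most directly on this is a number 47.1 percentage points lower from compound 2 to compound 3 (beyond the scatter), where the (dimethylamino)methyl-bearing chain was introduced and the number fell sharply; the step of a number 43 percentage points lower from compound 1 to compound 3 (beyond the scatter) points the same way. Both steps concern a chain ending in dimethylamino, which compound 4 retains, so the large fall is expected to be kept for the most part. For the measured compounds named here, the shortening of the chain has no direct precedent here, so some loss is allowed for. Compound 4 is therefore expected at 50%, with a range from 30% to 72%, meaning an expected step of a number 12 percentage points higher from compound 3 to compound 4 (beyond the scatter).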

Compound 4, a percentage reported as activity, at one concentration (the size of the read-out at that concentration, not a potency): 50.8%
Estimate against measurement, compound 4: 0.8 percentage points below, and the stated range covers the measured number.
By their numbers in this assay, from the lowest: compound 3; then compound 4; then compounds 1 and 2 (each within the scatter of the next).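

In this assay, the large fall does not depend on the 3-(dimethylamino)propyl chain alone: the 2-(dimethylamino)ethyl chain on the amine nitrogen also gives a clear separation from the two compounds without a dimethylamino group, seen in the step of a number 30.2 percentage points lower from compound 1 to compound 4 (beyond the scatter) and the step of a number 34.3 percentage points lower from compound 2 to compound 4 (beyond the scatter) on the same scale. Placing dimethylamino in place of (dimethylamino)methyl on the saturated chain carbon, two bonds along the chain from an amine nitrogen, still matters, since it gives a number 12.8 percentage points higher from compound 3 to compound 4 (beyond the scatter) and so shows that the length of this chain alters the read-out, though by less than the presence of the dimethylamino-bearing chain does. Nothing measured here accounts for either the effect of the chain or the effect of its length.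

The compounds shown leave open whether a longer chain, such as a 4-(dimethylamino)butyl group, would carry the trend further, since only two chain lengths can be set against each other here. They also leave open whether the terminal dimethylamino group itself is needed, or whether a primary amine, a piperidine ring or a hydroxyl group at the end of the same chain would serve as well.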